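Acetamido chromones: hydroxy addition and tolerated concentration

The source may report more compounds than this note shows. Statements on the series, on what has been measured and on what is new or still open speak of the compounds shown alone.

Measured compounds in an ADME assay on MT4 cells (Homo sapiens) for cytotoxicity, read by MTT assay, with a stated time of 4 days; a lower number here means that less compound is tolerated, a higher number that more compound is tolerated:
compound 1 `CC(=O)Nc1ccc2oc(-c3ccccc3)cc(=O)c2c1`: 184000 nM
compound 2 `COc1ccccc1-c1cc(=O)c2cc(NC(C)=O)ccc2o1`: 226000 nM
compound 3 `CC(=O)Nc1ccc2oc(-c3ccccc3F)cc(=O)c2c1`: 205000 nM

Compound 2 shows the highest of the three numbers in this assay, but it is not separated from the others: a 1.2-fold higher number from compound 1 to compound 2 (0.09 log units; within the scatter) and a 1.1-fold lower number from compound 2 to compound 3 (0.04 log units; within the scatter) both fall within the scatter, as does a 1.1-fold higher number from compound 1 to compound 3 (0.05 log units; within the scatter). Across these three compounds, exchanging hydrogen, methoxy and fluoro on the pendant aryl carbon leaves the tolerated concentration in one narrow band.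

Compound 4 `COc1ccccc1-c1oc2ccc(NC(C)=O)cc2c(=O)c1O` is not yet measured in this assay. It differs from compound 2 by hydroxy in place of hydrogen on an aromatic carbon. Among the compounds with values here, none of the measured steps involves a hydroxy group or a change on the core; all three concern the pendant aryl ring and all lie within the scatter. What they offer for the new step is only this: the shared core carrying the acetamido group has so far given a tolerated concentration that small substituent changes have not moved. No step beyond the scatter is therefore expected; the estimate corresponds to a 1.1-fold lower number from compound 2 to compound 4 (0.05 log units; within the scatter). Compound 4 is expected to give about 200000 nM in this assay, within a range from 100000 nM to 400000 nM. Within the data shown here, the range is set wide, as no measured step covers a hydroxy addition at this position.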

Compound 4, half-maximal cytotoxic concentration: 385000 nM
Beside the measured number, compound 4's estimate is 1.9-fold (0.28 log units) below it, and the stated range covers the measured number.
By their numbers in this assay, from the lowest: compounds 1, 3, 2 and 4 (each within the scatter of the next, the first and the last beyond it).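

Within the data shown here, this is the first change on the shared core rather than on the pendant ring: hydroxy in place of hydrogen, on the aromatic carbon ortho to a 2-methoxyphenyl group and ortho to a group of 1 heavy atom, gives a 1.7-fold higher number from compound 2 to compound 4 (0.23 log units; within the scatter) in this assay. Among these compounds, the position therefore accepts this hydroxy group without a step beyond the scatter, so the reading from the pendant ring, where no step left the scatter, now extends to one site on the core, though only with 2-methoxyphenyl as the pendant group. No measurement on hand bears on what lies behind the size of this step.

Whether the same addition stays within the scatter with the unsubstituted phenyl of compound 1 or the 2-fluorophenyl of compound 3 remains open, as there is no hydroxy counterpart of either among the compounds shown. Also open, on these data alone, is how this position responds to a group other than hydroxy, such as a methoxy, an amine, a carboxylic acid or a longer alkoxy chain, and whether any of these would produce a step beyond the scatter.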